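Aryl piperazine amides as mGlu5 positive allosteric modulators

The source may report more compounds than this note shows. Statements on the series, on what has been measured and on what is new or still open speak of the compounds shown alone.

Measured compounds:
compound 1 `O=C(COCc1ccncc1)N1CCN(c2ccc(F)cc2F)CC1`, 4600 nM
compound 2 `O=C(COCc1ccccn1)N1CCN(c2ccc(Cl)cc2Cl)CC1`, 310 nM

Of the compounds shown here, two have been measured in a functional assay on HEK293 cells for positive allosteric modulation of metabotropic glutamate receptor 5 (Homo sapiens), read by FLIPR and calcium flux; a higher number here means that more compound is needed for the effect, a lower number that less compound is needed. Compound 1 gives 4600 nM. Compound 2 gives 310 nM, the lower of the two numbers; the gap from compound 1 to compound 2 lies beyond the usual scatter. The two differ in more than one place, so only what their two values show can be said.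

Compound 3 `O=C(COCc1cccs1)N1CCN(c2ccc(Cl)cc2Cl)CC1` has not yet been measured in this assay. Relative to compound 2, the change is thiophen-2-yl in place of pyridin-2-yl on a saturated chain carbon bound to an oxygen on a saturated carbon. The dichlorophenyl piperazine amide portion of compound 2 is kept. Going by the values given here, no measured pair shows this change, so its size here cannot be read from the series. The exchange of one small aromatic ring for another at this position is expected to cost little or to remain within the scatter, so a step from compound 2 to compound 3 of a 1.6-fold higher number from compound 2 to compound 3 (0.21 log units; within the scatter) is estimated. Compound 3 is therefore expected to give 500 nM in this assay, with a range from 150 nM to 2000 nM.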

Compound 3, half-maximal effective concentration: > 310 nM
Compound 3: no number, only a limit; the forecaster's own chance of this, stated with the estimate: 10%; the middle value does not contradict the limit.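

In this assay compound 3 gives > 310 nM, which is a limit of the assay and not a number. Going by these compounds alone, with the dichlorophenyl piperazine amide portion kept, this is the first comparison that differs in one place, and thiophen-2-yl in place of pyridin-2-yl on a saturated chain carbon bound to an oxygen on a saturated carbon gives a number no lower from compound 2 to compound 3 (the limit leaves the size open), so this exchange brings no gain over pyridin-2-yl at this position. The size of the step cannot be read, because the value for compound 3 is a limit: the limit of > 310 nM in this assay, at which 1 of the 3 values shown sits.

The compounds shown leave open whether any other group at this position, such as a plain phenyl ring, a furan-2-yl ring or a pyridin-2-yl ring carrying an amine, would give a lower number than compound 2 does. Compound 1 and compound 2 also differ in more than one place, so how far the fluorine and chlorine substituents on the phenyl ring, taken apart from the pyridine ring, account for the gap between those two compounds remains unresolved.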